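This account rests on a few compounds, and the source may have more. Where it says the series, first, only, none or still open, it means among the compounds named here.

In an ADME assay on MRC5 cells (Homo sapiens) for cytotoxicity, read by fluorescence and resazurin assay, with a stated time of 3 days (on this read-out higher numbers stand for lower toxicity in this test and lower numbers for higher toxicity in this test), compound 2 `N#Cc1ccc(C2CCN(C(=O)Nc3cc(-c4ccccn4)n[nH]3)CC2)cc1` gives > 64000 nM, which is a limit and not a number. Compound 1 `O=C(Nc1cc(-c2ccccn2)n[nH]1)N1CCC(c2cccc(F)c2)CC1` gives > 64000 nM, also a limit. Compound 3 `O=C(Nc1cc(-c2ccccn2)n[nH]1)N1CCC(c2ccc(Cl)cc2)CC1` gives > 62000 nM, again a limit. Compound 2 therefore has no exact place on this scale, and neither do the two compounds beside it.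

The next compound, compound 4 `O=C(Nc1cc(-c2ccccn2)n[nH]1)N1CCC(c2ccccc2)CC1`, differs from compound 2 by one change: hydrogen in place of cyano on an aromatic carbon. Compound 4 thus carries phenyl where compound 2 carries 4-cyanophenyl.

The nearest measured change is chloro in place of cyano on an aromatic carbon, which gives a step that the two limits leave unreadable from compound 2 to compound 3. Changing the substituted phenyl group elsewhere in the set gives a step that the two limits leave unreadable from compound 1 to compound 2 and a step that the two limits leave unreadable from compound 1 to compound 3. None of these steps has a readable size, but all three compounds end at a limit. With a step that the two limits leave unreadable from compound 2 to compound 3 as the closest guide, no step beyond the usual scatter is expected in this assay, and a limit is the likely result again. The expected change is an at least 1.0-fold lower number from compound 2 to compound 4 (0.02 log units; that floor lies within the scatter). The estimate for compound 4 is 60000 nM, with an expected range from 30000 nM to 70000 nM.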

Compound 4, half-maximal cytotoxic concentration: > 64000 nM
Compound 4: no number, only a limit (the forecaster's own chance of this, stated with the estimate: 85%); at least 1.0-fold (0.02 log units) between middle value and limit.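

Compound 4 gives > 64000 nM, a limit and not a number. For the compounds shown here, compounds 1, 2 and 3 also end at limits, so no step to compound 4 can be read. The compounds shown leave open whether phenyl, 3-fluorophenyl, 4-chlorophenyl and 4-cyanophenyl differ at all in this assay.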